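Methyl on the terminal amide of compound 3

The source may hold more compounds than are shown below. What is called first, only, known or untested is meant among the compounds shown, and "the series" means these compounds.

Three analogues on the shared core have been tested in an ADME assay on CCRF-CEM cells (Homo sapiens) for cytotoxicity, with a stated time of 4 days; on this read-out higher numbers stand for lower toxicity in this test and lower numbers for higher toxicity in this test. Compound 1 `Cc1cn([C@@H]2O[C@H](CO[Si](C)(C)C(C)(C)C)[C@@]3(OS(=O)(=O)C=C3N)[C@H]2O[Si](C)(C)C(C)(C)C)c(=O)n(C(=O)c2ccccc2)c1=O` gives 54000 nM. Compound 2 `COC(=O)n1c(=O)c(C)cn([C@@H]2O[C@H](CO[Si](C)(C)C(C)(C)C)[C@@]3(OS(=O)(=O)C=C3N)[C@H]2O[Si](C)(C)C(C)(C)C)c1=O` reads > 100000 nM, which is a limit of the assay and not a number. Among the compounds with values here, compound 3 `Cc1cn([C@@H]2O[C@H](CO[Si](C)(C)C(C)(C)C)[C@@]3(OS(=O)(=O)C=C3N)[C@H]2O[Si](C)(C)C(C)(C)C)c(=O)n(C(=O)CCCC(N)=O)c1=O` gives 8700 nM, the lowest of the numbers so far, and compound 1 is its nearest neighbour.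

Compound 4 `CNC(=O)CCCC(=O)n1c(=O)c(C)cn([C@@H]2O[C@H](CO[Si](C)(C)C(C)(C)C)[C@@]3(OS(=O)(=O)C=C3N)[C@H]2O[Si](C)(C)C(C)(C)C)c1=O` differs from compound 3 by methyl in place of hydrogen on an amide-type nitrogen.

The measured steps all exchange the whole group on a carbonyl carbon. They are a 6.2-fold lower number from compound 1 to compound 3 (0.79 log units; beyond the scatter), an at least 11-fold lower number from compound 2 to compound 3 (1.06 log units; beyond the scatter) and an at least 1.8-fold higher number from compound 1 to compound 2 (0.26 log units; that floor lies within the scatter). None of them touches this amide nitrogen, so they bear on the new change only indirectly. The change is much smaller than the exchange behind a 6.2-fold lower number from compound 1 to compound 3 (0.79 log units; beyond the scatter), so no step beyond the scatter is expected in this assay. The expected result is a 1.1-fold higher number from compound 3 to compound 4 (0.06 log units; within the scatter). For compound 4 the estimated value is 10000 nM, with an expected range of 4000 nM to 26000 nM.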

Compound 4, half-maximal cytotoxic concentration: 9100 nM
Compound 4: the middle estimate sits 1.1-fold (0.04 log units) above what was measured; measured number inside the range.
By their numbers in this assay, from the lowest: compounds 3 and 4 (each within the scatter of the next); then compound 1. At a limit, above all of these: compound 2.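

In this assay, methyl in place of hydrogen on the amide-type nitrogen leaves the read-out within the scatter, so this position tolerates the change in this test: a 1.0-fold higher number from compound 3 to compound 4 (0.02 log units; within the scatter). The amide hydrogen is therefore not needed for the lower number relative to the phenyl carbonyl analogue, as the 3-(methylcarbamoyl)propyl group keeps a step of similar size: a 5.9-fold lower number from compound 1 to compound 4 (0.77 log units; beyond the scatter). Compound 2 reads as a limit of the assay and not a number, so its step stands only as a floor: an at least 10-fold lower number from compound 2 to compound 4 (1.04 log units; beyond the scatter).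

Open, going by these compounds, is whether the terminal amide itself matters, which a carboxylic acid at the end of the chain would test. Also open, on these data alone, is how a second methyl on this nitrogen, or a longer chain, would read.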